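The source may hold more compounds than are shown below. What is called first, only, known or untested is meant among the compounds shown, and "the series" means these compounds.

Measured compounds:
compound 1 `C[C@@H](O)CCn1nc2c(Br)c(Br)c(Br)c(Br)c2n1` — 71%
compound 2 `OC(CCn1nc2c(Br)c(Br)c(Br)c(Br)c2n1)c1ccccc1` — 84%
compound 3 `OC(CCn1nc2c(Br)c(Br)c(Br)c(Br)c2n1)c1ccc(Br)cc1` — 69%

All three share one core and were tested in a functional assay on CCRF-CEM cells (Homo sapiens) for antiproliferative activity, read by MTT assay, with a stated time of 48 h, tested at 25 uM; a lower number here means a stronger effect, a higher number a weaker effect of the compound at the concentration tested. Compound 1 stands second highest of the three numbers. Its nearest neighbour is compound 3, whose value lies within the usual scatter of compound 1, so no order between them can be read. Compound 2 lies further away, beyond the scatter, with the weaker effect of the three. Within the data shown here, the only step measured between two compounds that differ in one place is a number 15 percentage points lower from compound 2 to compound 3 (beyond the scatter), a modest change that concerns a bromo group on an aromatic carbon.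

Compound 4 `CC(O)CCn1nc2c(Br)c(Br)c(Br)c(Br)c2n1` is not yet measured. It differs from compound 1 in this way: the two compounds have the same atoms and bonds; at least one stereo element is drawn with a configuration in one of them and without one in the other: 1 of 1 stereo elements differ; a stereocentre at a saturated chain carbon is drawn R in compound 1 and without a configuration in compound 4. Among the measured compounds shown here, no measured step concerns such a change in drawn configuration; the step from compound 2 to compound 3 does not bear on it. With the same atoms and bonds present, no step beyond the scatter is expected in this assay. Compound 4 is therefore estimated at 72%, between 60% and 84%, which is expected to amount to a number 1 percentage points higher from compound 1 to compound 4 (within the scatter).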

Compound 4, a percentage reported as activity, at one concentration (the size of the read-out at that concentration, not a potency): 86%
Compound 4: middle estimate off by 14 percentage points, on the low side, outside the stated range (above it).
By their numbers in this assay, from the lowest: compounds 3 and 1 (each within the scatter of the next); then compounds 2 and 4 (each within the scatter of the next).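

In this assay, the steps at the saturated chain carbon bound to oxygen now include methyl as well as the two aromatic groups. Methyl in place of phenyl gives a number 2 percentage points higher from compound 2 to compound 4 (within the scatter), so that swap shows no readable change, while methyl in place of 4-bromophenyl gives a number 17 percentage points higher from compound 3 to compound 4 (beyond the scatter). More strikingly, a pair with the same atoms and bonds can still differ, as a number 15 percentage points higher from compound 1 to compound 4 (beyond the scatter) shows, and the one difference on record for this pair is this: the fact that one of compounds 1 and 4 is drawn with a defined configuration and the other without, at the place where they differ

The compounds shown leave open how a form drawn S at this carbon would read, and whether compound 4 is a single form or a mixture of forms. They also leave open what an ethyl group or a longer chain would do in place of the methyl at this carbon.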